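This account rests on a few compounds, and the source may have more. Where it says the series, first, only, none or still open, it means among the compounds named here.

Measured in a functional assay on HepG2 cells (Homo sapiens) for cytotoxicity, read by MTT assay, with a stated time of 72 h; on this read-out lower numbers stand for stronger inhibition and higher numbers for weaker inhibition:
Compound 1 `CNC(=O)c1cc(Oc2ccc(C(=O)/C=C/c3cccc(Br)c3)cc2)ccn1`: 2870 nM
Compound 2 `CNC(=O)c1cc(Oc2ccc(/C=C/C(=O)c3ccc(Br)cc3)cc2)ccn1`: 22000 nM
Compound 3 `CNC(=O)c1cc(Oc2ccc(C(=O)/C=C/c3ccc(Cl)cc3Cl)cc2)ccn1`: 11700 nM

Among these three, compound 1 shows the lowest number in this assay, with compound 3 as its nearest neighbour and compound 2 the furthest away. Compound 2 differs from compound 1 in more than one place, so its value is only a point of comparison, not a step.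

Compound 4 `CNC(=O)c1cc(Oc2ccc(C(=O)/C=C/c3cccc(Cl)c3Cl)cc2)ccn1` has not yet been measured. It differs from compound 1 as follows: 2,3-dichlorophenyl in place of 3-bromophenyl on a double-bonded chain carbon bound to a double-bonded chain carbon. Among the measured compounds shown here, the one measured step that bears on this is a 4.1-fold higher number from compound 1 to compound 3 (0.61 log units; beyond the scatter), where a dichlorophenyl also replaced the 3-bromophenyl at the same place. That step was modest but beyond the scatter. A change of the same kind is therefore expected here: a higher number than compound 1, roughly of that size, rather than no change.

For compound 4 the expected value is 8000 nM, within a range from 3000 nM to 22000 nM, which means an estimated step of a 2.8-fold higher number from compound 1 to compound 4 (0.45 log units; beyond the scatter).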

Compound 4, half-maximal inhibitory concentration: > 50000 nM
Compound 4 was reported as a limit; the forecaster's own chance of this, stated with the estimate: 5%; at least 6.2-fold (0.79 log units) between middle value and limit.
By their numbers in this assay, from the lowest: compound 1; then compounds 3 and 2 (each within the scatter of the next). At a limit, above all of these: compound 4.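

Compound 4 gives no exact number in this assay, only a limit: the limit of > 50000 nM in this assay, at which 1 of the 4 values shown sits. Even so, placing 2,3-dichlorophenyl on this chain carbon in place of 3-bromophenyl gives an at least 17-fold higher number from compound 1 to compound 4 (1.24 log units; beyond the scatter), showing that this change can cost far more than the earlier compounds suggested. The two dichlorophenyl groups are also not interchangeable, since 2,3-dichlorophenyl in place of 2,4-dichlorophenyl gives an at least 4.2-fold higher number from compound 3 to compound 4 (0.63 log units; beyond the scatter), so in this pair the arrangement of the two chlorines on the ring matters, and not merely their presence.

The compounds shown leave open how far the true value of compound 4 lies beyond its limit, and whether a single chlorine, as in 3-chlorophenyl, would behave like the bromine of compound 1. They also leave open how a phenyl ring carrying an amine or a carboxylic acid would read at this place.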